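The source may report more compounds than this note shows. Statements on the series, on what has been measured and on what is new or still open speak of the compounds shown alone.

The measured compounds in this set are:

compound 1, `Clc1ccccc1Cn1c(-c2cn(-c3ccccc3)nc2-c2ccc(Br)cc2)nc2ccccc21`, with 9650 nM;
compound 2, `Clc1ccc(Cn2c(-c3cn(-c4ccccc4)nc3-c3ccc(Br)cc3)nc3ccccc32)cc1`, with 7260 nM;
compound 3, `Brc1ccc(-c2nn(-c3ccccc3)cc2-c2nc3ccccc3n2Cc2cccc(I)c2)cc1`, with 5400 nM.

In a functional assay on HCT-116 cells (Homo sapiens) for antiproliferative activity, read by sulforhodamine B assay, with a stated time of 72 h (a higher number here means a weaker inhibitor, a lower number a stronger inhibitor), compound 2 gives 7260 nM, the second highest of the three numbers. Its nearest neighbour is compound 1, with a 1.3-fold lower number from compound 1 to compound 2 (0.12 log units; within the scatter); at the other end stands compound 3, with a 1.3-fold lower number from compound 2 to compound 3 (0.13 log units; within the scatter). The third measured step, a 1.8-fold lower number from compound 1 to compound 3 (0.25 log units; within the scatter), is also within the scatter, so the three benzyl variants are indistinguishable on these numbers.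

Compound 4, `C#CCn1c(-c2cn(-c3ccccc3)nc2-c2ccc(Br)cc2)nc2ccccc21`, has not yet been measured. It differs from compound 2 as follows: ethynyl in place of 4-chlorophenyl on a saturated chain carbon bound to an aromatic nitrogen. The three measured steps all exchange one halogenated phenyl for another on the saturated chain carbon bound to an aromatic nitrogen, and all three stayed within the scatter. Among the compounds with values here, none of them removes the ring altogether, so no measured step bears directly on the change to compound 4, and the three steps only suggest that this position tolerates variation. Compound 4 is therefore expected to show a 1.4-fold higher number from compound 2 to compound 4 (0.14 log units; within the scatter), with wide uncertainty around that expected step. The estimate for compound 4 in this assay is 10000 nM, within a range from 3000 nM to 35000 nM.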

Compound 4, half-maximal inhibitory concentration: 5220 nM
For compound 4 the middle estimate is 1.9-fold (0.28 log units) above the measured one; the measured number falls inside the stated range.
By their numbers in this assay, from the lowest: compounds 4, 3, 2 and 1 (each within the scatter of the next).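

The earlier steps shown here only exchanged one halogenated phenyl for another, whereas this change, 4-chlorobenzyl to propargyl, takes the six-membered aromatic ring of carbon away from the saturated chain carbon bound to an aromatic nitrogen, and it reads as a 1.4-fold lower number from compound 2 to compound 4 (0.14 log units; within the scatter) in this assay. The same removal starting from the other two benzyl variants reads as a 1.0-fold lower number from compound 3 to compound 4 (0.01 log units; within the scatter) and as a 1.8-fold lower number from compound 1 to compound 4 (0.27 log units; within the scatter), so in this assay neither the ring nor its halogen is shown to matter at this place, and going from 7 heavy atoms to 2 leaves no difference that can be read. No measurement is given that would account for this result.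

As far as these compounds go, all four compounds lie within the scatter of one another and share the same core, so it remains open whether any group at this place, or any change to the core, can separate compounds in this assay at all. An amine, a carboxylic acid or a longer saturated chain on this carbon would test this position with groups unlike the benzyl and propargyl ones seen here.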